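The source may hold more compounds than are shown below. What is called first, only, known or untested is meant among the compounds shown, and "the series" means these compounds.

Measured so far in a functional assay on U2OS cells for antagonist activity at proto-oncogene Wnt-3 (Homo sapiens), read by a luciferase reporter, with a stated time of 18 h; a higher number here means that more compound is needed for the effect, a lower number that less compound is needed:
compound 1 `O=C(Cn1ccnc1)N1CCC(NS(=O)(=O)c2cc(S(=O)(=O)c3ccccc3)ccc2C(F)(F)F)CC1` gives 230 nM
compound 2 `O=C([C@@H]1CCCN1C(=O)Nc1ccccc1)N1CCC(NS(=O)(=O)c2cc(S(=O)(=O)c3ccccc3)ccc2C(F)(F)F)CC1` gives 310 nM

Within the data shown here, compound 2 carries the higher of the two numbers, but its only neighbour, compound 1, sits within the scatter of it, so the two read as equivalent on this assay.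

The next member, compound 3 `CN(C)C(=O)N1CCC[C@H]1C(=O)N1CCC(NS(=O)(=O)c2cc(S(=O)(=O)c3ccccc3)ccc2C(F)(F)F)CC1`, follows from compound 2 by a single change: dimethylamino in place of anilino on a carbonyl carbon. Among the measured compounds shown here, no measured pair shows this change, and the two values at hand give no direction for it. The working expectation in this assay is therefore a step of about the size of the scatter or a little beyond, more likely towards a higher number than a lower one.

Compound 3 is estimated at 450 nM, with a range from 150 nM to 1400 nM. This estimate amounts to an expected 1.5-fold higher number from compound 2 to compound 3 (0.16 log units; within the scatter).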

Compound 3, half-maximal effective concentration: 160 nM
Compound 3: the middle estimate sits 2.8-fold (0.45 log units) above what was measured; the range from low to high includes it.
By their numbers in this assay, from the lowest: compounds 3, 1 and 2 (each within the scatter of the next).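

In this assay the step with dimethylamino in place of anilino on a carbonyl carbon, a 1.9-fold lower number from compound 2 to compound 3 (0.29 log units; within the scatter), lies within the scatter, so among these compounds a value in this range does not depend on the six-membered aromatic ring or the hydrogen-bond donor of anilino. With 1-(dimethylcarbamoyl)pyrrolidin-2-yl in place of (1H-imidazol-1-yl)methyl on a carbonyl carbon, a 1.4-fold lower number from compound 1 to compound 3 (0.16 log units; within the scatter) also lies within the scatter, so all three compounds read as equivalent. Nothing at hand bears on why these groups read alike.

Still open, going by these compounds, is whether a primary amine, a carboxylic acid or a longer alkyl chain on this carbonyl carbon would move the number beyond the scatter. The compounds shown also say nothing about changes to the shared core, which stays the same in all three.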